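Fluoro-to-hydroxy exchange on a pair of inactive acetylated diol cores

The compounds below may be only part of what the source reports. "The series", "measured", "known", "first", "only" and "open" are said of these compounds alone.

Of the compounds shown here, two have been tested in a functional assay on MIA PaCa-2 cells (Homo sapiens) for antiproliferative activity, read by MTT assay, with a stated time of 72 h (a lower number here means a stronger inhibitor, a higher number a weaker inhibitor), so far, and both reached the assay limit rather than a number. Compound 1 `COc1nc(CC(O)(COC(C)=O)COC(C)=O)c(C)c(OC)n1` gives > 100000 nM in this assay, which is a limit. Compound 2 `COc1nc(=O)n(C)c(CC(F)(COC(C)=O)COC(C)=O)c1C` also gives a limit in this assay, > 100000 nM. For the measured compounds named here, compound 2 therefore stands at the ceiling of the series; the shared limit is the only evidence available (the limit of > 100000 nM in this assay, at which 2 of the 2 values shown sit), and no ordering between compound 1 and compound 2 can be read from it.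

Compound 3 `COc1nc(=O)n(C)c(CC(O)(COC(C)=O)COC(C)=O)c1C` has not yet been measured in this assay. It differs from compound 2 by hydroxy in place of fluoro on a saturated chain carbon bound to three saturated chain carbons. Compound 1 already carries a hydroxy at the corresponding chain carbon on a different core and sits at the limit, so the same substituent on the core of compound 2 offers no basis for expecting a measurable number. The step from compound 2 to compound 3 is expected to be none beyond the scatter, with the most likely outcome another limit; the estimate for compound 3 is 100000 nM, within 40000 nM to 300000 nM, expressed as a step of a number no higher from compound 2 to compound 3 (the limit leaves the size open).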

Compound 3, half-maximal inhibitory concentration: > 100000 nM
Compound 3 ended at the assay's limit; the forecaster's own chance of this, stated with the estimate: 85%; the middle value lies on the limit itself.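

Compound 2 and compound 3 both sit at a limit in this assay, so no step between them can be read: the limit of > 100000 nM in this assay, at which 3 of the 3 values shown sit.

The compounds shown leave open whether hydroxy in place of fluoro on a saturated chain carbon bound to three saturated chain carbons changes anything in this assay, since none of them gives a measurable number there.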